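Working notes: the step from compound 3 to compound 4

A few compounds are considered here, and "the series" means these few. Any claim that something is new, unique, unknown or untested is made for them only; others in the source may bear on it.

Measured in an assay on isolated protein for inhibition of malate dehydrogenase, mitochondrial (Sus scrofa), with stated times of 45 min and 30 min (a higher number here means a weaker inhibitor, a lower number a stronger inhibitor), so far:
- compound 1, `O=S(=O)(Nc1ccc(-c2nc3ccccc3o2)cc1)c1ccccc1Cl`: compound 1 gives a limit, > 63000 nM
- compound 2, `CS(=O)(=O)Nc1ccc(-c2nc3ccccc3o2)cc1`: compound 2 gives a limit, > 63000 nM
- compound 3, `CCc1ccc(S(=O)(=O)Nc2ccc(-c3nc4ccccc4o3)cc2)cc1`: compound 3 gives a limit, > 63000 nM

Compound 3 stands only at a limit of this assay, not at a number. All three measured compounds sit at the same limit, (the limit of > 63000 nM in this assay, at which 3 of the 3 values shown sit), so none can be placed above or below the others. The steps among them are unreadable for the same reason: a step that the two limits leave unreadable from compound 1 to compound 2, a step that the two limits leave unreadable from compound 1 to compound 3 and a step that the two limits leave unreadable from compound 2 to compound 3 tell nothing about size or direction.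

Compound 4, `COc1ccc(S(=O)(=O)Nc2ccc(-c3nc4ccccc4o3)cc2)cc1`, is yet to be measured. It differs from compound 3 by methoxy in place of ethyl on an aromatic carbon. For the measured compounds named here, no measured step bears on this change beyond the fact that every variation at the sulfonyl sulfur so far has left the series at the limit. No step beyond the scatter is therefore expected in this assay, and compound 4 is expected to remain at or near the limit, with an estimated step that the limit leaves unreadable from compound 3 to compound 4. The estimate for compound 4 is 100000 nM, from 30000 nM to 400000 nM.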

Compound 4, half-maximal inhibitory concentration: > 63000 nM
Compound 4: a limit, no number (the forecaster's own chance of this, stated with the estimate: 85%); the middle value is on the limit's open side.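

In this assay, for the compounds shown here, compound 4 gives only a limit, > 63000 nM and so no step between it and compound 1, compound 2 or compound 3 can be read, all four sharing one limit: the limit of > 63000 nM in this assay, at which 4 of the 4 values shown sit. The compounds shown leave open whether any change on the shared core gives a measurable value in this assay and how these four compare with one another.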